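Swapping Chloro for Nitro on a Shared Core

The source may report more compounds than this note shows. Statements on the series, on what has been measured and on what is new or still open speak of the compounds shown alone.

Compound 1, `O=C(CCc1cccc2c1B(O)OC2)Nc1ccc(Cl)cc1`: 12000 nM
Compound 2, `O=C(CCc1cccc2c1B(O)OC2)Nc1ccc(Br)cc1`: 46000 nM
Compound 3, `COc1ccc(NC(=O)CCc2cccc3c2B(O)OC3)cc1`: 1700 nM

Of the compounds shown here, three sharing one core have been measured in a functional assay on HCT-116 cells (Homo sapiens) for antiproliferative activity, read by MTT assay, with a stated time of 72 h; on this read-out lower numbers stand for stronger inhibition and higher numbers for weaker inhibition. Compound 1 gives 12000 nM and stands second highest of the three; its nearest neighbour is compound 2 at 46000 nM, and its furthest is compound 3 at 1700 nM. Compound 4, `O=C(CCc1cccc2c1B(O)OC2)Nc1ccc([N+](=O)[O-])cc1`, has not yet been measured.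

Compound 4 differs from compound 1 as follows: nitro in place of chloro on an aromatic carbon. Two measured steps alter the same position of the shared core and so bear on this change. Bromo in place of chloro gave a 3.8-fold higher number from compound 1 to compound 2 (0.58 log units; beyond the scatter), while methoxy in place of chloro gave a 7.1-fold lower number from compound 1 to compound 3 (0.85 log units; beyond the scatter). The two steps run in opposite directions, and neither group resembles nitro, so there is no direct guide for the step from compound 1 to compound 4 in this assay.

On this basis a modest step in either direction is possible, and compound 4 is expected to give a 1.2-fold higher number from compound 1 to compound 4 (0.07 log units; within the scatter). Compound 4 is therefore estimated at 14000 nM, with a range from 3500 nM to 55000 nM.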

Compound 4, half-maximal inhibitory concentration: > 100000 nM
Compound 4: a limit, no number; the forecaster's own chance of this, stated with the estimate: 10%; at least 7.1-fold (0.85 log units) between middle value and limit.
By their numbers in this assay, from the lowest: compound 3; then compound 1; then compound 2. At a limit, above all of these: compound 4.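

In this assay compound 4 gives > 100000 nM, which is a limit of the assay and not a number: the limit of > 100000 nM in this assay, at which 1 of the 4 values shown sits. Nitro on this aromatic carbon, para to a large group, makes compound 4 the weakest of the four, with an at least 8.3-fold higher number from compound 1 to compound 4 (0.92 log units; beyond the scatter), an at least 2.1-fold higher number from compound 2 to compound 4 (0.33 log units; beyond the scatter) and an at least 58-fold higher number from compound 3 to compound 4 (1.76 log units; beyond the scatter). The earlier steps shown here had left the direction of a new group open, but this one runs the same way as bromo in place of chloro, a 3.8-fold higher number from compound 1 to compound 2 (0.58 log units; beyond the scatter), and against methoxy in place of chloro, a 7.1-fold lower number from compound 1 to compound 3 (0.85 log units; beyond the scatter), so the position is clearly sensitive to the group it carries, with compound 3 at one end of the series and compound 4 at the other.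

Because compound 4 sits at a limit, the true size of its steps stays unknown, and the four compounds show no rule that would explain their order. Going by these compounds, it also remains open whether an amine or a carboxylic acid on the same aromatic carbon would fall near compound 3, near compound 4 or somewhere else in this assay.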